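Alkyl thioether variation on a shared core

The source may report more compounds than this note shows. Statements on the series, on what has been measured and on what is new or still open speak of the compounds shown alone.

Measured compounds:
- compound 1, `CCCCNc1nc(SCC)nc2ncccc12`: 25300 nM
- compound 2, `CCCCNc1nc(SC(C)C)nc2ncccc12`: 32100 nM
- compound 3, `CCCCCCCNc1nc(SC(C)C)nc2ncccc12`: 24400 nM

In a functional assay on HT-29 cells (Homo sapiens) for cytotoxicity, read by neutral red uptake, with a stated time of 72 h (on this read-out lower numbers stand for stronger inhibition and higher numbers for weaker inhibition), compound 2 gives the highest of the three numbers, but its nearest neighbour compound 1 and its furthest neighbour compound 3 both lie within the scatter of it, so no ordering among the three can be read from these values.

Compound 4, `CCCCNc1nc(SCCCC)nc2ncccc12`, differs from compound 2 by butyl in place of isopropyl on a sulfur. Among the compounds with values here, two measured steps touch this question. The step of a 1.3-fold higher number from compound 1 to compound 2 (0.10 log units; within the scatter) changes the chain on the sulfur and stays within the scatter. The step of a 1.3-fold lower number from compound 2 to compound 3 (0.12 log units; within the scatter) lengthens the other chain, the one on the nitrogen on the aromatic ring, and also stays within the scatter. Neither step gives any sign that the size or branching of a saturated chain at either position moves the read-out of this assay, within the range covered by compounds 1 to 3.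

For compound 4 the expectation is therefore a number close to that of compound 2, with an estimated step of a 1.1-fold lower number from compound 2 to compound 4 (0.06 log units; within the scatter). The estimate for compound 4 in this assay is 28000 nM, with a range from 12000 nM to 65000 nM.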

Compound 4, half-maximal inhibitory concentration: 13600 nM
For compound 4 the middle estimate is 2.1-fold (0.31 log units) above the measured one; low and high end bracket the measured number.
By their numbers in this assay, from the lowest: compounds 4, 3, 1 and 2 (each within the scatter of the next, the first and the last beyond it).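

In this assay, within the data shown here, the chain on the sulfur now gives the first step beyond the scatter: butyl in place of isopropyl on a sulfur gives a 2.4-fold lower number from compound 2 to compound 4 (0.37 log units; beyond the scatter) and is a modest change. The other new step, ethyl in place of hydrogen on a saturated chain carbon, two bonds along the chain from a sulfur, gives a 1.9-fold lower number from compound 1 to compound 4 (0.27 log units; within the scatter) and stays within the scatter, so compound 4 separates from compound 2 but not from compound 1. The position on the sulfur is therefore not wholly indifferent to the chain it carries, but this rests on one modest step, and nothing available bears on what lies behind it.

Still open, as far as these compounds go, is whether a longer chain such as hexyl, or a benzyl group, on the sulfur continues this trend or whether the series levels off at butyl. Also open, from the compounds shown here alone, is whether butyl on the sulfur gives a similar step when the nitrogen on the aromatic ring carries the longer chain of compound 3.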